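A few compounds are considered here, and "the series" means these few. Any claim that something is new, unique, unknown or untested is made for them only; others in the source may bear on it.

Measured compounds:
- Compound 1 `Cc1nc(-c2cc3ccccc3o2)sc1COc1ccc2c(c1)OCC2CC(=O)O`: in a functional assay on CHO cells for agonist activity at Free fatty acid receptor 1 (Homo sapiens), read by FLIPR and calcium flux (on this read-out higher numbers stand for an effect only at larger amounts of compound and lower numbers for an effect already at smaller amounts), compound 1 gives "not determined" (no result reported)
- Compound 2 `Cc1nc(-c2cccc(Cl)c2)sc1COc1ccc2c(c1)OCC2CC(=O)O`: 138 nM

Compound 2 holds the only number shown in this assay, compound 1 having no result. Compound 3 `Cc1nc(-c2ccc(Cl)cc2)sc1COc1ccc2c(c1)OCC2CC(=O)O` differs from compound 2 in one place: 4-chlorophenyl in place of 3-chlorophenyl on an aromatic carbon. Within the data shown here, no step between measured compounds is available, so the size of this change rests on the structural change alone. A modest step is expected, with no direction supported beyond the scatter. Compound 3 is therefore estimated at 180 nM, within 60 nM to 550 nM, which means an expected step of a 1.3-fold higher number from compound 2 to compound 3 (0.12 log units; within the scatter).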

Compound 3, half-maximal effective concentration: 85.6 nM
For compound 3 the middle estimate is 2.1-fold (0.32 log units) above the measured one; the measured number falls inside the stated range.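

Placing 4-chlorophenyl in place of 3-chlorophenyl on this aromatic carbon gives the first step at this position in this assay: a 1.6-fold lower number from compound 2 to compound 3 (0.21 log units; within the scatter). On this read-out compound 2 and compound 3 cannot be told apart, so the two chlorophenyl groups are equivalent here within the scatter. Nothing available explains this result. Compound 1 carries no number, so the position is known only through these two chlorophenyl groups. From the compounds shown here alone, how it responds to a plain phenyl, a 2-chlorophenyl or a pyridine ring remains open.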